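A few compounds are considered here, and "the series" means these few. Any claim that something is new, unique, unknown or untested is made for them only; others in the source may bear on it.

Compound 1, `Cc1nc(COc2ccc(/C=C3\SC(=O)NC3=O)cc2)cs1`, tested in a functional assay on the whole organism (plasma, strain Wistar) with Rattus norvegicus as the target, with a stated time of 15 days, at a dose of 30 mg/kg by the oral route; a higher number here means a stronger effect of the compound at the dose given, a lower number a weaker effect: compound 1 gives 14.7%.
Compound 2, `O=C1NC(=O)/C(=C/c2ccc(OCCSc3nnc(-c4ccc([N+](=O)[O-])cc4)[nH]3)cc2)S1`: compound 2 gives 16%.
Compound 3, `O=C1NC(=O)/C(=C/c2ccc(OCCSc3nnc(-c4ccc(Cl)cc4)[nH]3)cc2)S1`: compound 3 gives 23.7%.

Among these three numbers compound 2 stands second highest. Compound 1 lies a little lower and compound 3 somewhat higher, but both gaps fall within the usual scatter of this assay, so the three compounds cannot be ranked against each other on these data.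

The next compound, compound 4, `COc1ccc(-c2nnc(SCCOc3ccc(/C=C4\SC(=O)NC4=O)cc3)[nH]2)cc1`, differs from compound 2 in one place: methoxy in place of nitro on an aromatic carbon. Among the measured compounds shown here, only one measured step speaks to this kind of exchange on that aromatic carbon, the step of a number 7.7 percentage points higher from compound 2 to compound 3 (within the scatter), where a chloro took the place of the same nitro group. That step did not rise above the scatter. For the measured compounds named here, a methoxy is a different group from a chloro, so the comparison is loose, yet the single available precedent suggests that replacing the nitro at this aromatic carbon leaves the read-out in this assay roughly where it was.

The expected step from compound 2 to compound 4 is therefore a number 4 percentage points higher from compound 2 to compound 4 (within the scatter), which is no change beyond the scatter. Compound 4 is estimated at 20%, within a range from 8% to 32%.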

Compound 4, a percentage reported as activity, at one dose (the size of the read-out at that dose, not a potency): 40%
For compound 4 the middle estimate is 20 percentage points below the measured one; measured number above the stated range.
By their numbers in this assay, from the lowest: compounds 1, 2 and 3 (each within the scatter of the next); then compound 4.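

In this assay, the position on the aromatic carbon para to a large group now shows that it can respond to a change. Going from 4-nitrophenyl to 4-methoxyphenyl gives a number 24 percentage points higher from compound 2 to compound 4 (beyond the scatter), and methoxy in place of chloro at the same carbon gives a number 16.3 percentage points higher from compound 3 to compound 4 (beyond the scatter). Among the compounds shown here, the earlier exchange of nitro for chloro, a number 7.7 percentage points higher from compound 2 to compound 3 (within the scatter), could not separate those two groups, so this is the first sign that the choice of group here matters, and methoxy is the group that stands out among the three. Nothing measured alongside these numbers accounts for the rise.

What the compounds shown leave open is whether this rise belongs to methoxy alone or extends to related groups on the same carbon, such as a hydroxyl, an ethoxy or a dimethylamino group. Each number also comes from a single dose, so it gives the size of the effect at that dose and cannot show whether the same order of compounds would hold at other doses.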